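The compounds below may be only part of what the source reports. "The series", "measured", "known", "first", "only" and "open" are said of these compounds alone.

Of the compounds shown here, three on the shared core have been read in a functional assay on KB cells (Homo sapiens) for inhibition; on this read-out lower numbers stand for stronger inhibition and higher numbers for weaker inhibition. Compound 1 (`N/C(=N\O)c1cn([C@@H]2O[C@H](CO)[C@@H](O)[C@H]2O)c2nnnc(N)c12`) gives 1500 nM, compound 2 (`CCOC(=O)c1cn([C@@H]2O[C@H](CO)[C@@H](O)[C@H]2O)c2nnnc(N)c12`) gives 80000 nM, and compound 3 (`COC(=N)c1cn([C@@H]2O[C@H](CO)[C@@H](O)[C@H]2O)c2nnnc(N)c12`) gives 20000 nM, the second highest of the three numbers. The next entry is compound 4 (`NC(=S)c1cn([C@@H]2O[C@H](CO)[C@@H](O)[C@H]2O)c2nnnc(N)c12`), which differs from compound 3 by a group of 3 heavy atoms (1 carbon, 1 nitrogen, 1 sulfur; no ring) in place of a group of 4 heavy atoms (2 carbon, 1 nitrogen, 1 oxygen; no ring), on an aromatic carbon. The exchange sits on the carbon of the five-membered aromatic ring with 1 nitrogen, two ring bonds from the ring nitrogen. Among the measured compounds shown here, no measured step makes this exact exchange, so the guidance is indirect. Other exchanges at this carbon moved the number clearly: a 53-fold higher number from compound 1 to compound 2 (1.73 log units; beyond the scatter), a 13-fold higher number from compound 1 to compound 3 (1.12 log units; beyond the scatter) and a 4.0-fold lower number from compound 2 to compound 3 (0.60 log units; beyond the scatter). A step beyond the scatter is therefore expected. The group in compound 4 ends in an unsubstituted amino nitrogen, as does the group in compound 1 at 1500 nM, so the expected direction is toward a lower number, with a large step more likely than a modest one. The expected step is an 8.0-fold lower number from compound 3 to compound 4 (0.90 log units; beyond the scatter). Compound 4 is estimated at 2500 nM, with an expected range of 250 nM to 20000 nM.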

Compound 4, half-maximal inhibitory concentration: 2000 nM
Compound 4: the middle estimate sits 1.3-fold (0.10 log units) above what was measured; low and high end bracket the measured number.
By their numbers in this assay, from the lowest: compounds 1 and 4 (each within the scatter of the next); then compound 3; then compound 2.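

In this assay, the group in compound 4 sits well apart from the two groups without an unsubstituted amino nitrogen, with a 10-fold lower number from compound 3 to compound 4 (1.00 log units; beyond the scatter) and a 40-fold lower number from compound 2 to compound 4 (1.60 log units; beyond the scatter). Against compound 1 it shows a 1.3-fold higher number from compound 1 to compound 4 (0.12 log units; within the scatter), so two different groups ending in an unsubstituted amino nitrogen now share the low end of the series, and none of the four compounds goes against this pattern at this aromatic carbon. No supporting evidence is available to explain these differences.

Still open, going by these compounds, is whether the unsubstituted amino nitrogen alone is enough, a question that a primary amide, a nitrile or a carboxylic acid on this carbon would help settle. Also open, on these data alone, is whether the pattern holds when the rest of the shared core is changed.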